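This account rests on a few compounds, and the source may have more. Where it says the series, first, only, none or still open, it means among the compounds named here.

Of the compounds shown here, three have so far been measured in a functional assay on HeLa cells (Homo sapiens) for inhibition, read by CCK-8 assay, with a stated time of 48 h; on this read-out higher numbers stand for weaker inhibition and lower numbers for stronger inhibition. Compound 1 `COc1ccc(Oc2ccc(C(C)C)cc2-c2ccsc2S(=O)(=O)NCCNC(=S)Nc2ccc([N+](=O)[O-])cc2)cc1OC` gives 11900 nM in this assay, and compound 2 `COc1ccc(Oc2ccc(C(C)C)cc2-c2ccsc2S(=O)(=O)NCCNC(=O)Nc2cc(Cl)cc(Cl)c2)cc1OC` gives 11600 nM. These two differ in only one place: a group of 11 heavy atoms (7 carbon, 1 nitrogen, 1 oxygen, 2 chlorine; one six-membered aromatic ring of carbon only) in place of a group of 12 heavy atoms (7 carbon, 2 nitrogen, 2 oxygen, 1 sulfur; one six-membered aromatic ring of carbon only), on an amine nitrogen. That change made a 1.0-fold lower number from compound 1 to compound 2 (0.01 log units; within the scatter).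

Compound 3 `Cc1ccc(-c2ccsc2S(=O)(=O)NCCNC(=S)Nc2ccc([N+](=O)[O-])cc2)c(Oc2ccc(O)c(O)c2)c1` is built on a different core, and the difference between the two cores is not broken down here. In this assay compound 3 gives 6800 nM.

Compound 4 `Cc1ccc(-c2ccsc2S(=O)(=O)NCCNC(=O)Nc2cc(Cl)cc(Cl)c2)c(Oc2ccc(O)c(O)c2)c1` has not yet been measured. It is reached from compound 3 by the same change that leads from compound 1 to compound 2: a group of 11 heavy atoms (7 carbon, 1 nitrogen, 1 oxygen, 2 chlorine; one six-membered aromatic ring of carbon only) in place of a group of 12 heavy atoms (7 carbon, 2 nitrogen, 2 oxygen, 1 sulfur; one six-membered aromatic ring of carbon only), on an amine nitrogen. The place of the change is described in the same words for both pairs, so it is the same change carried out on the other core.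

The expectation for the new pair rests on the earlier pair, because that change made a 1.0-fold lower number from compound 1 to compound 2 (0.01 log units; within the scatter). The step from compound 3 to compound 4 is therefore expected to be no change at the digits printed from compound 3 to compound 4 (within the scatter). The estimate for compound 4 in this assay is 6800 nM, expected to lie between 3000 nM and 15000 nM.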

Compound 4, half-maximal inhibitory concentration: 6500 nM
Compound 4: middle estimate off by 1.0-fold (0.02 log units), on the high side, and the stated range covers the measured number.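

In this assay, putting the (3,5-dichlorophenyl)carbamoyl group on the amine nitrogen of the second core gave a 1.0-fold lower number from compound 3 to compound 4 (0.02 log units; within the scatter). Set beside the earlier pair, the change behaves alike on both cores: the same change on two cores in this assay, a 1.0-fold lower number (0.01 log units; within the scatter) from compound 1 to compound 2 and a 1.0-fold lower number (0.02 log units; within the scatter) from compound 3 to compound 4, 1.0-fold (0.01 log units) apart, within the scatter of two such steps. This shows that on these two cores the swap leaves the read-out within the scatter, so the flat result carried over from one core to the other, but two pairs say nothing about a third core, and a flat step does not show that the two groups act alike in any respect other than this read-out.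

The change replaces a whole group at once, so the compounds shown leave open what the sulfur atom, the nitro group and the two chlorines each contribute, and whether their contributions happen to cancel. Also open, on these data alone, is whether a different group on that nitrogen, such as an acetyl group or a carboxylic acid, or a longer chain in place of the two-carbon link, would move the number beyond the scatter.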